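Adding a ring hydroxy to the more potent prostanoid acid

A few compounds are considered here, and "the series" means these few. Any claim that something is new, unique, unknown or untested is made for them only; others in the source may bear on it.

Of the compounds shown here, two of one family have been measured so far. Compound 1 `CCCCC1([C@H](O)/C=C/C2CCC(=O)[C@@H]2CCCCCC(=O)O)CCC1` carries a 4-carboxybutyl chain and in a functional assay on the whole organism (strain Hartley) for inhibition, with Cavia porcellus as the target, with stated times of 15 min and 2 min (a lower number here means that less compound is needed, a higher number that more compound is needed for the effect), compound 1 gives 0.32 mg/kg. Going by the values given here, compound 2 `CCCCC1([C@H](O)/C=C/C2CCC(=O)[C@@H]2C/C=C\CCCC(=O)O)CCC1` carries instead a 5-carboxypent-1-en-1-yl chain, and in this assay compound 2 gives 0.0242 mg/kg, the lowest of the two numbers; the only step so far is a 13-fold lower number from compound 1 to compound 2 (1.12 log units; beyond the scatter). Compound 3 `CCCCC1([C@H](O)/C=C/C2[C@H](O)CC(=O)[C@@H]2C/C=C\CCCC(=O)O)CCC1` differs from compound 2 by a (hydroxy in place of hydrogen on a saturated ring carbon). Among the compounds with values here, no measured step concerns a hydroxy entering a saturated ring carbon, so the one step recorded does not bear on this change and gives no direction for it. The expectation for compound 3 is therefore a step of a 1.2-fold lower number from compound 2 to compound 3 (0.08 log units; within the scatter), not beyond the scatter, with a wide range of uncertainty. Compound 3 is estimated at 0.02 mg/kg, between 0.004 mg/kg and 0.1 mg/kg.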

Compound 3, dose for half-maximal effect: 0.00106 mg/kg
Compound 3: middle estimate off by 19-fold (1.28 log units), on the high side; the measured number lies below the stated range.
By their numbers in this assay, from the lowest: compound 3; then compound 2; then compound 1.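

In this assay, a hydroxy in place of hydrogen on a saturated ring carbon, next to the ring atom that bears a large group, gives a 23-fold lower number from compound 2 to compound 3 (1.36 log units; beyond the scatter). The earlier compounds shown here showed a sensitivity to the chain only; this step shows that the five-membered ring is also far from silent, since one added oxygen on it makes a large difference to the dose needed, even with the favourable 6-carboxyhex-2-en-1-yl group already in place. Nothing measured here accounts for the size of this step.

Open, going by these compounds, is whether a methoxy group or a fluorine atom at this carbon would do the same, and whether the opposite spatial arrangement of the hydroxy would keep the gain. Also open, on these data alone, is whether the hydroxy would bring a similar step on the saturated 4-carboxybutyl chain of compound 1.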